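Flipping a double bond on a pyridine N-oxide

The compounds below may be only part of what the source reports. "The series", "measured", "known", "first", "only" and "open" are said of these compounds alone.

Compound 2 `CO/N=C(\CCN1CCC(c2cccc[n+]2[O-])CC1)c1ccc(Cl)cc1` gives the highest of the two values measured in a functional assay on HEK293 cells with D(4) dopamine receptor (Homo sapiens) as the target, read by FLIPR (a higher number here means a larger maximal response, a lower number a smaller maximal response), at 77%. Compound 1 `CO/N=C(/CCN1CCC(c2ccccn2)CC1)c1ccc(Cl)cc1` gives 10% in this assay, a much smaller maximal response. Compound 3 `CO/N=C(/CCN1CCC(c2cccc[n+]2[O-])CC1)c1ccc(Cl)cc1` is the next compound: the two compounds have the same atoms and bonds and differ only in configuration as drawn: 1 of 1 stereo elements differ; a double bond is drawn E in compound 2 and Z in compound 3. Among the measured compounds shown here, no measured pair differs in only this way, so the direction is uncertain, but since compound 1 shows 10% with the same drawn configuration, a downward step from compound 2 to compound 3 is expected, estimated at a number 37 percentage points lower from compound 2 to compound 3 (beyond the scatter). Compound 3 is expected to give about 40%, within 10% to 80%.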

Compound 3, largest response reached (reported as efficacy), in percent of the reference or control that the assay uses: 65%
Beside the measured number, compound 3's estimate is 25 percentage points below it; the measured number falls inside the stated range.
By their numbers in this assay, from the lowest: compound 1; then compound 3; then compound 2.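

With the double bond drawn the same way, the group carrying the added oxygen gives a number a number 55 percentage points higher from compound 1 to compound 3 (beyond the scatter) in this assay, so this position strongly affects the maximal response. Flipping the double bond has a smaller effect, giving a number a number 12 percentage points lower from compound 2 to compound 3 (beyond the scatter). This modest step isolates a single feature: the fact that compounds 2 and 3 differ only in the configuration as drawn.

The compounds shown leave open how the plain pyridine compound responds with its double bond drawn the other way. They also leave open how an amine or a carboxylic acid on the saturated ring carbon would perform.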